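Dimethylphenyl ketone to halogenated ring: a tolerance forecast

The source may hold more compounds than are shown below. What is called first, only, known or untested is meant among the compounds shown, and "the series" means these compounds.

Compound 3 `Cc1ccc(C(=O)c2c(OCC(=O)Nc3ccc(S(N)(=O)=O)cc3C)ccc3cc(Br)ccc23)c(C)c1` gives 61400 nM in an ADME assay on C8166 cells (Homo sapiens) for cytotoxicity, read by colorimetric assay and MTT assay (a lower number here means that less compound is tolerated, a higher number that more compound is tolerated), the highest of the three numbers measured. Compound 1 `Cc1cc(S(N)(=O)=O)ccc1NC(=O)COc1ccc2cc(Br)ccc2c1C(=O)c1ccccc1` gives 29200 nM and compound 2 `Cc1cccc(C(=O)c2c(OCC(=O)Nc3ccc(S(N)(=O)=O)cc3C)ccc3cc(Br)ccc23)c1` gives 6800 nM. Compound 4 `Cc1cc(S(N)(=O)=O)ccc1NC(=O)COc1ccc2cc(Br)ccc2c1C(=O)c1cc(Cl)cc(Br)c1` differs from compound 3 by 3-bromo-5-chlorophenyl in place of 2,4-dimethylphenyl on a carbonyl carbon. Within the data shown here, two measured steps touch the same place: a 2.1-fold higher number from compound 1 to compound 3 (0.32 log units; beyond the scatter) and a 9.0-fold higher number from compound 2 to compound 3 (0.96 log units; beyond the scatter), whereas a 4.3-fold lower number from compound 1 to compound 2 (0.63 log units; beyond the scatter) concerns another position. Among the measured compounds shown here, both changes leading to the 2,4-dimethylphenyl raised the number, but no measured compound carries a halogenated ring at the carbonyl carbon, so the direction for compound 4 is uncertain. Replacing the 2,4-dimethylphenyl is expected to move the number back toward that of compound 1, giving an expected 2.0-fold lower number from compound 3 to compound 4 (0.31 log units; beyond the scatter). Compound 4 is therefore estimated at 30000 nM, within a range from 8000 nM to 90000 nM.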

Compound 4, half-maximal cytotoxic concentration: 28500 nM
Estimate against measurement, compound 4: 1.1-fold (0.02 log units) above; the measured number falls inside the stated range.
By their numbers in this assay, from the lowest: compound 2; then compounds 4 and 1 (each within the scatter of the next); then compound 3.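

At the carbonyl carbon, the 3-bromo-5-chlorophenyl ring reads in this assay alongside plain phenyl (a 1.0-fold lower number from compound 1 to compound 4 (0.01 log units; within the scatter)), so this halogenated ring leaves no separation from the unsubstituted ring. The two methylated rings lie on opposite sides of it (a 2.2-fold lower number from compound 3 to compound 4 (0.33 log units; beyond the scatter); a 4.2-fold higher number from compound 2 to compound 4 (0.62 log units; beyond the scatter)), which shows that the spread at this place among these compounds comes from those two rings. Nothing available bears on why these rings differ. On these data alone, it remains open whether a single chlorine or a single bromine on the phenyl ring would give the same reading. Also open, as far as these compounds go, is how a ring carrying an amine or a carboxylic acid would read at this carbonyl carbon.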